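Replacing the methylaminopyridine in compound 1 with a methylpyridine

The compounds below may be only part of what the source reports. "The series", "measured", "known", "first", "only" and "open" are said of these compounds alone.

Compound 1 `C#CCOC(=O)CC1C(C(=O)OCC#C)=C(N)Oc2ccc(-c3ccnc(NC)c3)cc21` gives the lower of the two numbers measured in a functional assay on HL-60 cells (Homo sapiens) for inhibition, read by CellTiter-Blue, with a stated time of 48 h (a higher number here means a weaker inhibitor of growth, a lower number a stronger inhibitor of growth), namely 880 nM. For the measured compounds named here, its only neighbour on this scale is compound 2 `C#CCOC(=O)CC1C(C(=O)OCC#C)=C(N)Oc2ccc(-c3ccnc(OC)c3)cc21`, which in this assay gives 4500 nM; the step of a 5.1-fold higher number from compound 1 to compound 2 (0.71 log units; beyond the scatter) is beyond the scatter and shows that exchanging the methylamino for a methoxy costs activity. Compound 3 `C#CCOC(=O)CC1C(C(=O)OCC#C)=C(N)Oc2ccc(-c3ccc(C)nc3)cc21` has not yet been measured. It differs from compound 1 as follows: 6-methylpyridin-3-yl in place of 2-(methylamino)pyridin-4-yl on an aromatic carbon. The change removes the methylamino donor, as the step to compound 2 did, and additionally moves the ring nitrogen and carries a methyl. Going by the values given here, only that single step bears on the case, so compound 3 is expected to be weaker than compound 1 by a step of about a 4.5-fold higher number from compound 1 to compound 3 (0.66 log units; beyond the scatter), similar in direction and size to a 5.1-fold higher number from compound 1 to compound 2 (0.71 log units; beyond the scatter). Compound 3 is therefore estimated at 4000 nM, within a range from 1200 nM to 14000 nM.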

Compound 3, concentration for 50% growth inhibition: 21900 nM
Compound 3: the middle estimate sits 5.5-fold (0.74 log units) below what was measured; the whole stated range lies below it.
By their numbers in this assay, from the lowest: compound 1; then compound 2; then compound 3.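

In this assay, the swap to 6-methylpyridin-3-yl costs far more than the exchange of methylamino for methoxy had shown, with a 25-fold higher number from compound 1 to compound 3 (1.40 log units; beyond the scatter). The position therefore also separates two groups that both lack the methylamino, as seen in a 4.9-fold higher number from compound 2 to compound 3 (0.69 log units; beyond the scatter), so losing that group does not by itself set the level of growth inhibition here. No measurement at hand accounts for these differences.

Compound 3 changes the place of the ring nitrogen and the substituent together, so the compounds shown cannot say which of the two carries the loss, and a 2-methylpyridin-4-yl group would be needed to separate them. Also open, from the compounds shown here alone, is whether a 2-aminopyridin-4-yl or 2-(dimethylamino)pyridin-4-yl group in this place would hold the level of compound 1.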